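Removing the sulfonamide nitrogen substituent

A few compounds are considered here, and "the series" means these few. Any claim that something is new, unique, unknown or untested is made for them only; others in the source may bear on it.

Measured in a functional assay on SK-OV-3 cells (Homo sapiens) for antiproliferative activity, read by sulforhodamine B assay, with a stated time of 72 h; a lower number here means a stronger inhibitor, a higher number a weaker inhibitor:
- compound 1 `O=S(=O)(Nc1nccs1)c1ccc(Nc2nncc3ccccc23)cc1`: 7.7 nM
- compound 2 `Cc1cc(NS(=O)(=O)c2ccc(Nc3nncc4ccccc34)cc2)no1`: 6.7 nM

Compound 2, at 6.7 nM, lies within the scatter of compound 1, at 7.7 nM, so neither ranks ahead of the other. The next compound is compound 3 `NS(=O)(=O)c1ccc(Nc2nncc3ccccc23)cc1`, and the change is hydrogen in place of 5-methyl-1,2-oxazol-3-yl on a sulfonamide nitrogen.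

Going by the values given here, one measured step bears on this: a 1.1-fold lower number from compound 1 to compound 2 (0.06 log units; within the scatter). That step exchanges one substituent for another and lies within the scatter. Among the compounds with values here, no measured compound has an unsubstituted sulfonamide nitrogen, so the removal itself remains untested. A modest rise in the number is expected, with low confidence in its direction, and the expected step is a 1.8-fold higher number from compound 2 to compound 3 (0.25 log units; within the scatter). For compound 3 the estimated value is 12 nM (expected range 3 nM to 50 nM).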

Compound 3, half-maximal inhibitory concentration: 0.8 nM
Compound 3: middle estimate off by 15-fold (1.18 log units), on the high side, outside the stated range (below it).
By their numbers in this assay, from the lowest: compound 3; then compounds 2 and 1 (each within the scatter of the next).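

In this assay, going by these compounds alone, hydrogen on the sulfonamide nitrogen is the first change at this position to move the number beyond the scatter, and it does so from either substituted compound (an 8.4-fold lower number from compound 2 to compound 3 (0.92 log units; beyond the scatter)) (a 9.6-fold lower number from compound 1 to compound 3 (0.98 log units; beyond the scatter)). Neither 5-methyl-1,2-oxazol-3-yl nor 1,3-thiazol-2-yl is required for activity in these cells, and each goes with a higher number than hydrogen, with steps of similar size from the two substituted compounds. No measurement at hand accounts for the size of these steps.

Going by these compounds, it remains open whether a small group on this nitrogen, such as methyl or acetyl, keeps the number close to that of compound 3 (0.8 nM). On these data alone, it also remains open whether a non-aromatic group, such as a longer alkyl chain carrying an amine, behaves like hydrogen or like the two five-membered rings.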